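Shortening a hydroxyalkyl chain into a carboxylic acid

The source may report more compounds than this note shows. Statements on the series, on what has been measured and on what is new or still open speak of the compounds shown alone.

Measured compounds:
- compound 1, `O=C(O)COc1ccc(-c2coc3cc(OCC(=O)O)ccc3c2=O)cc1`: >> 9000 nM
- compound 2, `O=c1c(-c2ccc(O)cc2)coc2cc(OCCCCCCCCCO)ccc12`: 700 nM
- compound 3, `CCCCCCC(Oc1ccc2c(=O)c(-c3ccc(O)cc3)coc2c1)C(=O)OCC`: 7200 nM

All three compounds share one core and differ in what hangs from its ether oxygen. In an assay (Cricetulus griseus) for inhibition of aldehyde dehydrogenase, mitochondrial (Homo sapiens) (on this read-out higher numbers stand for weaker inhibition and lower numbers for stronger inhibition), compound 2 gives 700 nM, the lowest of the two numbers measured. Compound 3, carrying a branched ester chain, gives 7200 nM in this assay, a higher number that lies beyond the usual scatter. For compound 1, which carries two carboxymethyl groups, the result in this assay is only a limit of the assay, >> 9000 nM; this is the limit of >> 9000 nM in this assay, at which 1 of the 3 values shown sits.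

The unmeasured compound 4, `O=C(O)CCCCCCOc1ccc2c(=O)c(-c3ccc(O)cc3)coc2c1`, follows from compound 2 by one change: carboxy in place of 3-hydroxypropyl on a saturated chain carbon, six bonds along the chain from an oxygen on an aromatic ring. The chain thus becomes shorter and ends in an acid instead of an alcohol. Within the data shown here, no step between measured compounds shows this exact change, so the expectation rests on the two acid-bearing compounds giving the weaker readings. The step from compound 2 to compound 4 is expected to move this assay toward a higher number, clearly beyond the scatter, a 5.7-fold higher number from compound 2 to compound 4 (0.76 log units; beyond the scatter). Compound 4 is therefore estimated at 4000 nM, with a plausible range from 1200 nM to 15000 nM.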

Compound 4, half-maximal inhibitory concentration: 50 nM
Beside the measured number, compound 4's estimate is 80-fold (1.90 log units) above it; the measured number lies below the stated range.
By their numbers in this assay, from the lowest: compound 4; then compound 2; then compound 3. At a limit, above all of these: compound 1.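

Replacing 3-hydroxypropyl with carboxy on a saturated chain carbon, six bonds along the chain from an oxygen on an aromatic ring, gives a large change in this assay: a 14-fold lower number from compound 2 to compound 4 (1.15 log units; beyond the scatter). This shows that the end of this chain strongly influences the reading, and that a shorter chain ending in an acid can outperform the longer chain ending in an alcohol, with compound 4 at 50 nM. Nothing measured here explains why the acid-bearing chain gives the lower number.

On these data alone, the step changes two things at once, the chain length and its end group, so the share of each in the gain remains unknown. A chain of the same length as in compound 4 but ending in an alcohol, a longer chain ending in a carboxylic acid, or a chain ending in a primary amide or a methyl ester would help separate the two effects and show whether the acid itself matters.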